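Aryl to piperidinyl swap on the fused core

The compounds below may be only part of what the source reports. "The series", "measured", "known", "first", "only" and "open" are said of these compounds alone.

Three compounds have numbers in an assay on isolated protein for antagonist activity at prostaglandin E2 receptor EP1 subtype (Homo sapiens), read by reporter gene assay; on this read-out lower numbers stand for stronger inhibition and higher numbers for weaker inhibition. Compound 1 `O=C(O)c1csc(-n2nc(-c3ccccc3)c3c2CCCC3)n1` gives 16 nM in this assay. Compound 2 `O=C(O)c1csc(-n2nc(-c3ccccc3)c3c2CCCCC3)n1` gives 1000 nM in this assay. Compound 3 `O=C(O)c1csc(-n2nc(-c3ccc(F)cc3)c3ccccc32)n1` gives 4.5 nM in this assay, the lowest number of the three; compound 1 stands closest to it and compound 2 furthest, both gaps beyond the scatter. Within the data shown here, the three differ in more than one place from one another, so no single-point step between measured compounds is available.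

Compound 4 `O=C(O)c1csc(-n2nc(N3CCCCC3)c3ccccc32)n1` is the next entry, not yet measured. Against compound 3 the change is piperidin-1-yl in place of 4-fluorophenyl on an aromatic carbon. From the compounds shown here alone, every measured compound of the series carries a six-membered aromatic ring at this position, so a non-aromatic ring there is untested. Among the measured compounds shown here, a step toward weaker inhibition, beyond the scatter, is expected for compound 4, since compound 3 gives 4.5 nM and no measured compound stands stronger than compound 3 to suggest further gain. For compound 4 the estimate is 100 nM, within 15 nM to 800 nM, an expected step of a 22-fold higher number from compound 3 to compound 4 (1.35 log units; beyond the scatter).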

Compound 4, half-maximal inhibitory concentration: 16 nM
Beside the measured number, compound 4's estimate is 6.3-fold (0.80 log units) above it; the range from low to high includes it.
By their numbers in this assay, from the lowest: compound 3; then compounds 1 and 4 (each within the scatter of the next); then compound 2.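

Piperidin-1-yl in place of 4-fluorophenyl gives a 3.6-fold higher number from compound 3 to compound 4 (0.55 log units; beyond the scatter) in this assay, so the change has a measurable but modest cost. An aromatic ring of carbon only is therefore not required at this aromatic carbon of the five-membered ring on this core: compound 4 keeps 16 nM with a non-aromatic ring that brings in a ring nitrogen and one hydrogen-bond acceptor. No measured evidence accounts for the size of this step.

Open, from the compounds shown here alone, is whether cyclohexyl, which has no ring nitrogen, or morpholin-4-yl, which adds a ring oxygen, would hold inhibition at this position, and so whether the ring nitrogen matters to the result. Also open, going by these compounds, is whether piperidin-1-yl would give a similar result on the core of compound 1.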